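A few compounds are considered here, and "the series" means these few. Any claim that something is new, unique, unknown or untested is made for them only; others in the source may bear on it.

Measured so far in an assay on isolated protein for inhibition of lysosomal alpha-glucosidase (Homo sapiens), read by fluorescence, with stated times of 5 min and 45 min; on this read-out higher numbers stand for weaker inhibition and lower numbers for stronger inhibition:
- compound 1, `O=C1Cc2cc(S(=O)(=O)N3CCN(c4ccc([N+](=O)[O-])cc4)CC3)ccc2N1`: 3660 nM
- compound 2, `O=C1Cc2cc(S(=O)(=O)N3CCN(c4ccc(F)cc4)CC3)ccc2N1`: "not active" (no number reported)

Compound 2 stands without a single number in this assay; for it only the outcome "not active" (no number reported) is recorded, while compound 1 gives 3660 nM in the same assay. Within the data shown here, no step between the two can be stated beyond what these two results show: one compound with a number, one without.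

Compound 3, `O=C1Cc2cc(S(=O)(=O)N3CCN(c4ccc(CO)cc4)CC3)ccc2N1`, has not yet been measured in this assay. The change from compound 2 reads (hydroxymethyl in place of fluoro on an aromatic carbon), that is, 4-fluorophenyl to 4-(hydroxymethyl)phenyl on the shared core.

With no numbered step from compound 2 available, the direction of this change in this assay cannot be read from the data; the expectation for compound 3 is drawn only from the result of compound 1 and the absence of a number for compound 2. Compound 3 is estimated at 12000 nM, with a range from 2500 nM to 60000 nM, and a real chance that this assay again reports no number.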

Compound 3, half-maximal inhibitory concentration: 13000 nM
Beside the measured number, compound 3's estimate is 1.1-fold (0.03 log units) below it; measured number inside the range.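

Hydroxymethyl, on the aromatic carbon para to a large group, gives a measurable number in this assay, so a numbered result at this position is not confined to the nitro group of compound 1. Hydroxymethyl in place of nitro gives a 3.6-fold higher number from compound 1 to compound 3 (0.55 log units; beyond the scatter) and thus shows that the position responds to the group it carries, although only modestly for this pair. The step from compound 2 to compound 3 cannot be read, as compound 2 has the outcome "not active" and no number.

No measured property of these groups is available to account for the results. Open, going by these compounds, is how an amine, a carboxylic acid or a longer chain ending in hydroxyl would read at this position, and whether any of them would reach a lower number than compound 1 gives.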